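Methoxy added beside the fluoro anilide of compound 2

This account rests on a few compounds, and the source may have more. Where it says the series, first, only, none or still open, it means among the compounds named here.

Compound 2 `O=C(Nc1ccc(-c2cn[nH]c2)cc1F)C1COc2ccccc2C1` gives 80 nM in an assay on cells for inhibition of Rho-associated protein kinase 2 (Homo sapiens) (a higher number here means a weaker inhibitor, a lower number a stronger inhibitor), the highest of the three numbers in hand. Compound 3 `O=C(Nc1cc(F)c(-c2cn[nH]c2)c(F)c1)C1COc2ccccc2C1` gives 15 nM and compound 1 `COc1cc(NC(=O)C2COc3ccccc3C2)ccc1-c1cn[nH]c1` gives 7 nM; both gaps to compound 2 lie beyond the scatter. Compound 4 `COc1cc(NC(=O)C2COc3ccccc3C2)c(F)cc1-c1cn[nH]c1` differs from compound 2 by methoxy in place of hydrogen on an aromatic carbon, the methoxy standing ortho to the 1H-pyrazol-4-yl group and para to the fluoro group. Going by the values given here, no single change between measured compounds matches this; compound 1, the one measured compound carrying a methoxy, shows the lowest number in this assay, whereas compound 2 carries none. The step from compound 2 to compound 4 is expected to lower the number beyond the scatter, by a 5.3-fold lower number from compound 2 to compound 4 (0.73 log units; beyond the scatter). Compound 4 is estimated at 15 nM, within 5 nM to 50 nM.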

Compound 4, half-maximal inhibitory concentration: 8 nM
Compound 4: the middle estimate sits 1.9-fold (0.27 log units) above what was measured; the measured number falls inside the stated range.
By their numbers in this assay, from the lowest: compounds 1, 4 and 3 (each within the scatter of the next, the first and the last beyond it); then compound 2.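

In this assay, going by these compounds alone, methoxy in place of hydrogen on this aromatic carbon, ortho to a 1H-pyrazol-4-yl group and para to a fluoro group, gives a 10-fold lower number from compound 2 to compound 4 (1.00 log units; beyond the scatter), the first single-change reading at this position. With the methoxy present, fluoro in place of hydrogen gives a 1.1-fold higher number from compound 1 to compound 4 (0.06 log units; within the scatter), so this change shifts the number no further than the scatter. No measurement at hand bears on the reason for the methoxy step.

From the compounds shown here alone, whether ethoxy, hydroxyl or an amine on this carbon would match methoxy stays open. Going by these compounds, the step for the fluoro group without the methoxy also stays open.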